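Dropping the nitro group from a dihydrostilbene phenol

The source may report more compounds than this note shows. Statements on the series, on what has been measured and on what is new or still open speak of the compounds shown alone.

Measured compounds:
compound 1, `COc1cc(CCc2cccc(F)c2)cc(OC)c1O`: 7570 nM
compound 2, `COc1ccccc1CCc1cc(OC)c(O)c(OC)c1`: 14500 nM
compound 3, `COc1cc(CCc2ccc([N+](=O)[O-])cc2)cc(OC)c1O`: 3160 nM

In a functional assay on HCT-116 cells (Homo sapiens) for antiproliferative activity, read by MTT assay, with a stated time of 72 h (on this read-out higher numbers stand for weaker inhibition and lower numbers for stronger inhibition), compound 3 gives 3160 nM, the lowest of the three numbers; compound 1 stands above it by a gap beyond the scatter, and compound 2 stands furthest away, also beyond the scatter. All three share the same core, and they differ only in what sits on the second aromatic ring.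

Compound 4, `COc1cc(CCc2ccccc2)cc(OC)c1O`, has not yet been measured. It differs from compound 3 in one place: hydrogen in place of nitro on an aromatic carbon. The nitro group is removed and nothing takes its place but a hydrogen atom, on an aromatic carbon of a six-membered aromatic ring of carbon only. For the measured compounds named here, no measured pair here shows this exact change, so the size of the step cannot be read from the data.

Going by the values given here, since compound 3 carries the lowest number of the set and compound 4 gives up the only group on that ring, compound 4 is expected to move toward the other two, a step of about a 2.5-fold higher number from compound 3 to compound 4 (0.40 log units; beyond the scatter) in this assay. Compound 4 is estimated at 8000 nM, within the range 3000 nM to 25000 nM.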

Compound 4, half-maximal inhibitory concentration: 530 nM
Beside the measured number, compound 4's estimate is 15-fold (1.18 log units) above it; measured number outside the range, below it.
By their numbers in this assay, from the lowest: compound 4; then compound 3; then compounds 1 and 2 (each within the scatter of the next).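

In this assay, for the compounds shown here, hydrogen in place of nitro on an aromatic carbon, para to a large group, gives a 6.0-fold lower number from compound 3 to compound 4 (0.78 log units; beyond the scatter) and shows that the nitro group, carried by the best of the earlier compounds, is no gain at this place. Hydrogen in place of methoxy gives a 27-fold lower number from compound 2 to compound 4 (1.44 log units; beyond the scatter) and hydrogen in place of fluoro gives a 14-fold lower number from compound 1 to compound 4 (1.15 log units; beyond the scatter) on the same read-out. The earlier compounds shown here could only be ranked among themselves, whereas the ring with no substituent now shows that all three groups stand above it in number, and no compound here goes against this.

As far as these compounds go, whether an amine, a hydroxyl group or a carboxylic acid on this ring could match hydrogen remains open. Nothing measured here explains why the unsubstituted ring gives the lowest number.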